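Aryl amide swap and cytotoxicity limits in the series

This account rests on a few compounds, and the source may have more. Where it says the series, first, only, none or still open, it means among the compounds named here.

In an ADME assay on Karpas-1106P cells (Homo sapiens) for cytotoxicity (a higher number here means that more compound is needed for the effect, a lower number that less compound is needed), compound 1 `Cc1ccc(S(=O)(=O)N[C@@H](CC(=O)NC(C)(C)C)C(=O)NCCNC(=O)c2cc(C)ccc2F)cc1` gives > 11100 nM, a limit of the assay.
In this assay compound 2 `Cc1ccc(S(=O)(=O)N[C@@H](CC(=O)NC(C)(C)C)C(=O)NCCNC(=O)c2cc(Cl)ccc2Cl)cc1` gives > 11100 nM, a limit of the assay.
In this assay compound 3 `Cc1ccc(S(=O)(=O)N[C@@H](CC(=O)NC(C)(C)C)C(=O)NCCNC(=O)c2ccc(F)cc2)cc1` gives > 11100 nM, a limit of the assay.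

Compound 3 therefore stands where every measured member of the series stands, at the limit of > 11100 nM in this assay, at which 3 of the 3 values shown sit. No value in this assay is a number, so none of the three compounds can be ordered against another.

The steps among them confirm this: a step that the two limits leave unreadable from compound 1 to compound 2, a step that the two limits leave unreadable from compound 1 to compound 3 and a step that the two limits leave unreadable from compound 2 to compound 3. Each exchange of the aryl group on the carbonyl carbon leaves the read-out in this assay at the limit, and no size can be assigned to any of them.

Compound 4 `Cc1ccc(S(=O)(=O)N[C@@H](CC(=O)NC(C)(C)C)C(=O)NCCNC(=O)c2ccccn2)cc1` continues the same kind of exchange: pyridin-2-yl in place of 4-fluorophenyl on a carbonyl carbon. For the measured compounds named here, the three unreadable steps are the only evidence bearing on it, and they show no effect in this assay that rises out of the limit. No step beyond the scatter is expected; the estimated step from compound 3 is a step that the limit leaves unreadable from compound 3 to compound 4.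

For compound 4 the expected value in this assay is 15000 nM, with an estimated range from 5000 nM to 45000 nM, most probably again reported only as a limit.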

Compound 4, half-maximal effective concentration: > 11100 nM
Compound 4: no number, only a limit (the forecaster's own chance of this, stated with the estimate: 80%); the middle value is on the limit's open side.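

Compound 4 is reported in this assay only as a limit, as are compound 1, compound 2 and compound 3, so no new step to compound 4 can be read: the limit of > 11100 nM in this assay, at which 4 of the 4 values shown sit.

The compounds shown leave open whether any group on the carbonyl carbon gives a numerical read-out in this assay, and how these four compounds order there.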